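Trading trifluoromethoxy for trifluoromethyl on compound 2

The compounds below may be only part of what the source reports. "The series", "measured", "known", "first", "only" and "open" are said of these compounds alone.

Going by the values given here, only two compounds have numbers so far. In a functional assay on HCT-116 cells (Homo sapiens) for antiproliferative activity, read by MTT assay, with a stated time of 72 h (a lower number here means a stronger inhibitor, a higher number a weaker inhibitor), compound 1 `O=S1(=O)C=Cc2ccc(Nc3cccc(C(F)(F)F)c3)cc21` gives 1370 nM. In this assay, compound 2 `O=S1(=O)C=Cc2cccc(Nc3ccc(OC(F)(F)F)cc3)c21` gives 2380 nM. These two values lie within the usual scatter of repeated measurements, so the data do not separate them. The two compounds differ in more than one place, so they do not show the effect of any single change.

Compound 3 `O=S1(=O)C=Cc2cccc(Nc3ccc(C(F)(F)F)cc3)c21` keeps the rest of compound 2 and changes one group: trifluoromethyl in place of trifluoromethoxy on an aromatic carbon, para to a large group (trifluoromethyl in place of trifluoromethoxy on an aromatic carbon). Among the compounds with values here, no measured pair shows this exchange, so the expectation is only a cautious one. Within the data shown here, compound 1 also carries a trifluoromethyl group and gives 1370 nM, a number within the scatter of the one for compound 2. On that slim evidence, no change beyond the scatter is expected. The expected step of a 1.2-fold lower number from compound 2 to compound 3 (0.08 log units; within the scatter) is therefore small, and its direction is uncertain. For compound 3 the estimated value is 2000 nM, with an expected range from 800 nM to 5000 nM.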

Compound 3, half-maximal inhibitory concentration: 1440 nM
The estimate for compound 3 lay 1.4-fold (0.14 log units) above the measured number; low and high end bracket the measured number.
By their numbers in this assay, from the lowest: compounds 1, 3 and 2 (each within the scatter of the next).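

Going by these compounds alone, compound 2 and compound 3 form the first pair here that differs in one place only, so the exchange of trifluoromethoxy for trifluoromethyl on an aromatic carbon, para to a large group, can now be read directly. In this assay the exchange gives a 1.7-fold lower number from compound 2 to compound 3 (0.22 log units; within the scatter) and therefore does not separate the two groups, even though the oxygen of trifluoromethoxy is gone from compound 3. At this position, then, these two fluorinated groups cannot be told apart by this measurement, and no data on any other property of the compounds are available to explain the result.

On these data alone, with only these two groups compared at this position, it remains open whether a group of a different kind, such as an amine, a carboxylic acid or a longer alkyl chain, would move the number beyond the scatter or leave it in the same range. As far as these compounds go, it also remains open whether the same exchange would stay within the scatter if the group were attached elsewhere on the ring or the shared core were altered.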